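The source may hold more compounds than are shown below. What is called first, only, known or untested is meant among the compounds shown, and "the series" means these compounds.

Measured compounds:
- compound 1 `CC1CC/C(=N\Nc2ccccc2O)c2ncc(C(=O)O)c(=O)n21`: 208000 nM
- compound 2 `COc1ccc(N/N=C2\CCC(C)n3c2ncc(C(=O)O)c3=O)cc1`: 128000 nM

In a functional assay (mast cells) for inhibition, with Rattus norvegicus as the target (on this read-out lower numbers stand for an effect already at smaller amounts and higher numbers for an effect only at larger amounts of compound), compound 1 gives 208000 nM and compound 2 gives 128000 nM. Among the measured compounds shown here, the only measured step, a 1.6-fold lower number from compound 1 to compound 2 (0.21 log units; within the scatter), lies within the scatter, so compound 2 and compound 1 cannot be told apart on these numbers; both act only at very large amounts of compound.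

Compound 3 `CNC(=O)c1ccc(N/N=C2\CCC(C)n3c2ncc(C(=O)O)c3=O)cc1` keeps the core of compound 2 and differs from it in one place: methylcarbamoyl in place of methoxy on an aromatic carbon. For the measured compounds named here, no measured step shows this particular change. Going by the values given here, the one step available, a 1.6-fold lower number from compound 1 to compound 2 (0.21 log units; within the scatter), swapped a whole substituted ring and still did not move the number beyond the scatter, which gives no ground to expect a shift here either. Compound 3 is therefore expected to stay close to compound 2, with a 1.0-fold higher number from compound 2 to compound 3 (0.01 log units; within the scatter) as the expected step. The estimate for compound 3 is 130000 nM, with a range from 40000 nM to 400000 nM.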

Compound 3, half-maximal effective concentration: 100000 nM
For compound 3 the middle estimate is 1.3-fold (0.11 log units) above the measured one; measured number inside the range.
By their numbers in this assay, from the lowest: compounds 3, 2 and 1 (each within the scatter of the next, the first and the last beyond it).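

In this assay, the change on an aromatic carbon para to a large group gives a 1.3-fold lower number from compound 2 to compound 3 (0.11 log units; within the scatter), so compound 2 and compound 3 cannot be told apart. Among the compounds shown here, this is the first view of a change confined to this one substituent, since the earlier step replaced a whole substituted ring. Methylcarbamoyl is larger than methoxy and carries a hydrogen-bond donor that methoxy lacks, yet neither difference produces a change in the number that exceeds the scatter, and no independent measurement is available to interpret this result.

Still open, as far as these compounds go, is whether an amine or a longer chain at this same position would move the number beyond the scatter. It is also unknown whether any group placed here could produce an effect at much smaller amounts of compound.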